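This account rests on a few compounds, and the source may have more. Where it says the series, first, only, none or still open, it means among the compounds named here.

In a functional assay on PC-3 cells (Homo sapiens) for antiproliferative activity, read by MTT assay, with a stated time of 24 h (a higher number here means a weaker inhibitor, a lower number a stronger inhibitor), compound 2 `CCn1c(C(=O)NCCC(=O)OC)ccc1C(CC)(CC)c1ccc(OCS(=O)(=O)c2ccccc2)c(C)c1` gives 40400 nM, the highest of the two numbers reported. Compound 3 `CCn1c(C(=O)NCCN)ccc1C(CC)(CC)c1ccc(OCS(=O)(=O)c2ccccc2)c(C)c1` gives 6890 nM in this assay. The step of a 5.9-fold lower number from compound 2 to compound 3 (0.77 log units; beyond the scatter) carries amino in place of methoxycarbonyl on a saturated chain carbon, two bonds along the chain from an amide-type nitrogen. Compound 1 `CCn1c(C(=O)N[C@H](C)C(=O)OC)ccc1C(CC)(CC)c1ccc(OCS(=O)(=O)c2ccccc2)c(C)c1` reaches only a limit of this assay, > 50000 nM. Compound 4 `CCn1c(C(=O)NCC(=O)O)ccc1C(CC)(CC)c1ccc(OCS(=O)(=O)c2ccccc2)c(C)c1` differs from compound 2 by carboxy in place of (methoxycarbonyl)methyl on a saturated chain carbon bound to an amide-type nitrogen; cut one bond further out, the same difference reads 2-(methoxycarbonyl)ethyl to carboxymethyl. Within the data shown here, the only measured step that also removes the methoxycarbonyl group is a 5.9-fold lower number from compound 2 to compound 3 (0.77 log units; beyond the scatter), yet there an amino group entered rather than carboxy, so it bears only loosely. A small step toward a lower number, or none beyond the scatter, is expected. Compound 4 is estimated at 25000 nM, between 8000 nM and 60000 nM. That estimate means an expected step of a 1.6-fold lower number from compound 2 to compound 4 (0.21 log units; within the scatter).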

Compound 4, half-maximal inhibitory concentration: 30100 nM
Estimate against measurement, compound 4: 1.2-fold (0.08 log units) below; low and high end bracket the measured number.
By their numbers in this assay, from the lowest: compound 3; then compounds 4 and 2 (each within the scatter of the next). At a limit, above all of these: compound 1.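

With carboxy in place of (methoxycarbonyl)methyl on a saturated chain carbon bound to an amide-type nitrogen, the result is a 1.3-fold lower number from compound 2 to compound 4 (0.13 log units; within the scatter), so this change shows no difference beyond the scatter. With carboxy in place of aminomethyl, the result is a 4.4-fold higher number from compound 3 to compound 4 (0.64 log units; beyond the scatter), so among these compounds the lower number goes with the amine end of the chain. Compound 1 stands at a limit: the limit of > 50000 nM in this assay, at which 1 of the 4 values shown sits. Its step can therefore be given only as a floor: an at least 1.6-fold lower number from compound 1 to compound 4 (0.22 log units; that floor lies within the scatter).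

On these data alone, whether a longer chain ending in an amine would lower the number further remains open. So does whether a longer chain ending in a carboxylic acid would differ from the shorter one.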